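This account rests on a few compounds, and the source may have more. Where it says the series, first, only, none or still open, it means among the compounds named here.

Compound 1 `Cc1c(F)c(N)c2c(=O)cc(-c3ccc(N)c(F)c3)oc2c1F`, compound 2 `Nc1ccc(-c2cc(=O)c3c(N)c(F)c(CO)c(F)c3o2)cc1F` and compound 3 `CCCCCCCCCC(=O)OCc1c(F)c(N)c2c(=O)cc(-c3ccc(N)c(F)c3)oc2c1F` share one core and were each tested in a functional assay on MCF7 cells (Homo sapiens) for cytotoxicity, read by neutral red uptake, with a stated time of 3 days; a lower number here means a stronger inhibitor, a higher number a weaker inhibitor. Compound 1 gives 13 nM, compound 2 gives 62 nM and compound 3 gives 100 nM. Compound 2 thus holds the second-highest number of the three, closest to compound 3 and furthest from compound 1. Compound 4 `COCc1c(F)c(N)c2c(=O)cc(-c3ccc(N)c(F)c3)oc2c1F` is not yet measured; it differs from compound 2 by methyl in place of hydrogen on an oxygen on a saturated carbon. Within the data shown here, two measured steps bear on this: a 4.8-fold higher number from compound 1 to compound 2 (0.68 log units; beyond the scatter) and a 1.6-fold higher number from compound 2 to compound 3 (0.21 log units; within the scatter). The second step alters the same oxygen and moves the number little, so only a small shift is expected here. Compound 4 is therefore expected to stay close to its parent, a step of a 1.2-fold higher number from compound 2 to compound 4 (0.08 log units; within the scatter). Compound 4 is estimated at 75 nM, with a range from 35 nM to 160 nM.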

Compound 4, half-maximal inhibitory concentration: 46 nM
Compound 4: the middle estimate sits 1.6-fold (0.21 log units) above what was measured; measured number inside the range.
By their numbers in this assay, from the lowest: compound 1; then compounds 4, 2 and 3 (each within the scatter of the next, the first and the last beyond it).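

Methyl on this oxygen leaves the number within the scatter in this assay (a 1.3-fold lower number from compound 2 to compound 4 (0.13 log units; within the scatter)), so the hydroxy hydrogen is not needed to keep it there. The group on this oxygen now makes a difference beyond the scatter: methyl and nonylcarbonyl are separated (a 2.2-fold lower number from compound 3 to compound 4 (0.34 log units; beyond the scatter)), which hydrogen and nonylcarbonyl were not. Methoxy on the saturated chain carbon also remains beyond the scatter from hydrogen there (a 3.5-fold higher number from compound 1 to compound 4 (0.55 log units; beyond the scatter)). From the compounds shown here alone, how an ethyl ether, an acetyl ester or an amine at this place would read remains open. Nothing available explains these steps.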